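Moving the Bromine on a Benzyl Ether

A few compounds are considered here, and "the series" means these few. Any claim that something is new, unique, unknown or untested is made for them only; others in the source may bear on it.

Compound 1 `COc1cc(OC)c(-c2coc3cc(OCC=C(C)C)ccc3c2=O)cc1OC` gives 3800 nM in a functional assay on HUVEC cells (Homo sapiens) for antiproliferative activity, read by MTT assay, with a stated time of 24 h; on this read-out higher numbers stand for weaker inhibition and lower numbers for stronger inhibition. Compound 2 `COc1cc(OC)c(-c2coc3cc(OCc4ccc(F)cc4)ccc3c2=O)cc1OC` sits at a limit of the assay, > 10000 nM. Compound 3 `COc1cc(OC)c(-c2coc3cc(OCc4ccc(Br)cc4)ccc3c2=O)cc1OC` likewise sits at a limit, > 10000 nM. Accordingly an at least 2.6-fold higher number from compound 1 to compound 2 (0.42 log units; beyond the scatter) and an at least 2.6-fold higher number from compound 1 to compound 3 (0.42 log units; beyond the scatter), whereas a step that the two limits leave unreadable from compound 2 to compound 3; two of the three values rest on (the limit of > 10000 nM in this assay, at which 2 of the 3 values shown sit). Compound 4 `COc1cc(OC)c(-c2coc3cc(OCc4cccc(Br)c4)ccc3c2=O)cc1OC` differs from compound 3 by 3-bromophenyl in place of 4-bromophenyl on a saturated chain carbon bound to an oxygen on an aromatic ring. Among the compounds with values here, no measured pair separates the two bromo positions, so the only bearing is that both benzyl ethers, compound 2 and compound 3, reach the limit. Within the data shown here, compound 4 is therefore expected to remain near that limit, with a number no higher from compound 3 to compound 4 (the limit leaves the size open) expected to be no step readable beyond the scatter. The estimate for compound 4 is 10000 nM, between 4000 nM and 25000 nM.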

Compound 4, half-maximal inhibitory concentration: > 10000 nM
Compound 4 gave a limit, no number; the forecaster's own chance of this, stated with the estimate: 70%; the middle value sits exactly at the limit.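

Moving the bromine from 4-bromophenyl to 3-bromophenyl does not lift the benzyl ether off the limit: compound 4 gives > 10000 nM, which is a limit and not a number. The gap to the 2-methylprop-1-en-1-yl ether therefore holds for a third benzyl ether, with an at least 2.6-fold higher number from compound 1 to compound 4 (0.42 log units; beyond the scatter). The steps among compound 2, compound 3 and compound 4 cannot be read, because all three rest on the same limit: the limit of > 10000 nM in this assay, at which 3 of the 4 values shown sit.

Left open is how far past the limit these three lie. Also open, on these data alone, is whether a benzyl ether carrying an amine or a carboxylic acid, or a longer chain in its place, would come back toward compound 1.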